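This account rests on a few compounds, and the source may have more. Where it says the series, first, only, none or still open, it means among the compounds named here.

Measured compounds:
compound 1 `Cc1ccc(-c2c(C)nn(-c3nc(-c4ccc(Cl)c(Cl)c4)c(SC(C)C)s3)c2C(=O)O)cc1` — 3800 nM
compound 2 `Cc1c(-c2cc(Cl)cc(Cl)c2)c(C(=O)O)nn1-c1nc(-c2cc(Cl)ccc2F)c(SC(C)C)s1` — 4800 nM
compound 3 `Cc1c(-c2cc(Cl)cc(Cl)c2)c(C(=O)O)nn1-c1nc(-c2cnn(C)c2)c(SC(C)C)s1` — "not active" (no number reported)

In a functional assay on BJAB cells (Homo sapiens) for antiproliferative activity, with a stated time of 4 days (a higher number here means that more compound is needed for the effect, a lower number that less compound is needed), compound 1 gives 3800 nM. Compound 2 gives 4800 nM, and the two numbers are within the scatter of each other, so neither can be placed ahead of the other. Compound 3 is reported only as "not active" (no number reported), without a number. For the measured compounds named here, no pair of measured compounds differs in a single place, so the size of any one change cannot be read from these three.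

Compound 4 `COc1ccc(-c2c(C)nn(-c3nc(-c4ccc(Cl)c(Cl)c4)c(SC(C)C)s3)c2C(=O)O)cc1` differs from compound 1 by methoxy in place of methyl on an aromatic carbon. Going by the values given here, with no comparable step available, no shift beyond the scatter is expected in either direction. Compound 4 is expected to give 4000 nM, with a range from 1500 nM to 11000 nM. The expected step from compound 1 to compound 4 is a 1.1-fold higher number from compound 1 to compound 4 (0.02 log units; within the scatter), within the scatter.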

Compound 4, half-maximal effective concentration: 2100 nM
Compound 4: middle estimate off by 1.9-fold (0.28 log units), on the high side, and the stated range covers the measured number.
By their numbers in this assay, from the lowest: compounds 4, 1 and 2 (each within the scatter of the next, the first and the last beyond it).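

For the compounds shown here, the change from 4-methylphenyl to 4-methoxyphenyl gives a 1.8-fold lower number from compound 1 to compound 4 (0.26 log units; within the scatter) in this assay and is the first single-place comparison. At this position, para to a large group, methoxy in place of methyl therefore produces no shift distinguishable from repeat measurement. No available measurement bears on the reason for this result.

Still open, from the compounds shown here alone, is whether a dimethylamino group or a longer chain such as butoxy at this position would move the number beyond the scatter.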